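A few compounds are considered here, and "the series" means these few. Any claim that something is new, unique, unknown or untested is made for them only; others in the source may bear on it.

Measured so far in a functional assay on HepG2 cells (Homo sapiens) for inhibition, read by MTT assay, with a stated time of 72 h; a higher number here means a weaker inhibitor, a lower number a stronger inhibitor:
- compound 1, `Nc1ncnc2c1c(-c1cnc3[nH]ccc3c1)nn2CC(=O)NO`: > 150000 nM
- compound 2, `Nc1ncnc2c1c(-c1cnc3[nH]ccc3c1)nn2CCCCCC(=O)NO`: 12900 nM
- compound 3, `Nc1nc2cc(-c3nn(CCCCCC(=O)NO)c4ncnc(N)c34)ccc2o1`: 1990 nM

Compound 1 returns only a limit of this assay, > 150000 nM, and not a number; this is the case recorded as the limit of > 150000 nM in this assay, at which 1 of the 3 values shown sits. Compound 2, in this assay, gives 12900 nM. The change from compound 2 to compound 1 is hydroxycarbamoyl in place of 4-(hydroxycarbamoyl)butyl on a saturated chain carbon bound to an aromatic nitrogen, and it produced an at least 11-fold higher number from compound 2 to compound 1 (1.06 log units; beyond the scatter). Among the compounds with values here, compound 3 gives 1990 nM in this assay, the lowest of the two numbers so far. How the core of compound 3 differs from that of compound 2 is not broken down here.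

Compound 4, `Nc1nc2cc(-c3nn(CC(=O)NO)c4ncnc(N)c34)ccc2o1`, is not yet measured. It stands to compound 3 as compound 1 stands to compound 2: hydroxycarbamoyl in place of 4-(hydroxycarbamoyl)butyl on a saturated chain carbon bound to an aromatic nitrogen, at the same place, so the same change. On the strength of an at least 11-fold higher number from compound 2 to compound 1 (1.06 log units; beyond the scatter), a step of comparable size is expected here, a 20-fold higher number from compound 3 to compound 4 (1.30 log units; beyond the scatter), with the outcome uncertain since the earlier step ended at a limit. The expected value for compound 4 in this assay is 40000 nM, within 12000 nM to 150000 nM.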

Compound 4, half-maximal inhibitory concentration: > 150000 nM
Compound 4: only a limit was reported; the forecaster's own chance of this, stated with the estimate: 25%; middle value at least 3.7-fold (0.57 log units) away from the limit.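

In this assay, the change from 4-(hydroxycarbamoyl)butyl to hydroxycarbamoyl on a saturated chain carbon bound to an aromatic nitrogen gives an at least 75-fold higher number from compound 3 to compound 4 (1.87 log units; beyond the scatter), so the direction seen on the core of compound 2 holds on the core of compound 3, and this rests on these two cores alone. Compound 4 gives > 150000 nM, which is a limit of the assay and not a number. The direction therefore carries over, but whether the step has the same size on both cores stays unresolved: the same change on two cores in this assay, an at least 11-fold higher number (1.06 log units; beyond the scatter) from compound 2 to compound 1 and an at least 75-fold higher number (1.87 log units; beyond the scatter) from compound 3 to compound 4; the limit leaves it open whether they differ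

The compounds shown leave open how the number changes for chains of intermediate length or for a longer chain than 5-(hydroxycarbamoyl)pentyl on either core, and so whether the rise is gradual or abrupt. They also leave open what the hydroxycarbamoyl end contributes apart from the chain, which a carboxylic acid at the end of the same chain could separate.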